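The compounds below may be only part of what the source reports. "The series", "measured", "known", "first", "only" and "open" are said of these compounds alone.

Values so far in a physicochemical assay for solubility, read by spectrophotometry, in phosphate buffer, with a stated time of 18 h, at pH 7.4; a lower number here means a less soluble compound, a higher number a more soluble compound:

- compound 1 `Cc1ccc(-c2nc3c(c(C)nn3-c3ccccc3)c(-c3ccccc3O)c2C#N)cc1` gives 26000 nM
- compound 2 `Cc1cccc(-c2nc3c(c(C)nn3-c3ccccc3)c(-c3ccccc3O)c2C#N)c1` gives 42000 nM
- compound 3 `Cc1ccccc1-c1nc2c(c(C)nn2-c2ccccc2)c(-c2ccccc2O)c1C#N` gives 21000 nM

Compound 3 (21000 nM) cannot be separated from the other two compounds, as a 1.2-fold lower number from compound 1 to compound 3 (0.09 log units; within the scatter) and a 2.0-fold lower number from compound 2 to compound 3 (0.30 log units; within the scatter) are both within the scatter. Compound 4 `Cc1nn(-c2ccccc2)c2nc(-c3ccc(C(C)C)cc3)c(C#N)c(-c3ccccc3O)c12` is the next to be read, and the change is 4-isopropylphenyl in place of 2-methylphenyl on an aromatic carbon. This places 4-isopropylphenyl on the aromatic carbon ortho to the cyano group. The closest evidence is the set of moves of the methyl group around the same phenyl, where a 1.6-fold higher number from compound 1 to compound 2 (0.21 log units; within the scatter) is also within the scatter, as is a 1.2-fold lower number from compound 1 to compound 3 (0.09 log units; within the scatter) in the comparison above. Among the compounds with values here, no measured compound carries the 4-isopropylphenyl group, so that part of the change is untested. No step beyond the scatter in this assay is therefore expected, with only a slight lean to a lower number. The estimated change is a 1.2-fold lower number from compound 3 to compound 4 (0.09 log units; within the scatter) and remains tentative. The expected value for compound 4 is 17000 nM (6000 nM to 40000 nM).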

Compound 4, solubility: 9800 nM
Estimate against measurement, compound 4: 1.7-fold (0.24 log units) above, within the range that was stated.
By their numbers in this assay, from the lowest: compound 4; then compounds 3, 1 and 2 (each within the scatter of the next).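

In this assay the moves of the methyl group around the phenyl stayed within the scatter, so this position had shown no separation until 4-isopropylphenyl gave a 2.1-fold lower number from compound 3 to compound 4 (0.33 log units; beyond the scatter) and a 4.3-fold lower number from compound 2 to compound 4 (0.63 log units; beyond the scatter) in the same direction. The closest comparison is a 2.7-fold lower number from compound 1 to compound 4 (0.42 log units; beyond the scatter) where only isopropyl takes the place of methyl, so a change of this alkyl group alone is enough to step beyond the scatter here. Nothing available bears on the reason for this drop.

On these data alone, whether the fall continues with a tert-butyl group or a longer chain on the phenyl remains open, as does the outcome for 3-isopropylphenyl. The compounds shown also leave open how an amine or a carboxylic acid on this phenyl would read.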